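The compounds below may be only part of what the source reports. "The series", "measured", "known", "first", "only" and "open" are said of these compounds alone.

Working notes on the diamine series.

Compound 1 `Nc1cc(N)c2nc(-c3ccccc3)c(NCc3ccc(Cl)c(Cl)c3)nc2c1` carries the 3,4-dichlorophenyl group; in a functional assay on NCI-H460 cells (Homo sapiens) for inhibition, read by sulforhodamine B assay, with a stated time of 48 h (on this read-out lower numbers stand for stronger inhibition of growth and higher numbers for weaker inhibition of growth), compound 1 gives 46800 nM. Compound 2 `COc1ccc(CNc2nc3cc(N)cc(N)c3nc2-c2ccccc2)cc1OC` replaces that group with the 3,4-dimethoxyphenyl group; in this assay compound 2 gives 91200 nM. Among the measured compounds shown here, the single measured step, a 1.9-fold higher number from compound 1 to compound 2 (0.29 log units; within the scatter), is within the scatter, so the two compounds cannot be ordered, and compound 2 simply stands at the higher of the two numbers so far.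

Compound 3 `COc1cc(CNc2nc3cc(N)cc(N)c3nc2-c2ccccc2)cc(OC)c1OC` is to be measured. The change from compound 2 is methoxy in place of hydrogen on an aromatic carbon. For the measured compounds named here, no measured step adds a methoxy group to a ring that already carries two; the only step available exchanges two chlorines for two methoxy groups, and it stayed within the scatter. With nothing pointing in either direction, no step beyond the scatter is expected in this assay.

The implied step a 1.0-fold higher number from compound 2 to compound 3 (0.02 log units; within the scatter) is therefore expected to stay within the scatter. Compound 3 is estimated at 95000 nM, with a range of 40000 nM to 230000 nM.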

Compound 3, concentration for total growth inhibition: < 50200 nM
Compound 3: only a limit was reported (the forecaster's own chance of this, stated with the estimate: 20%); middle value at least 1.8-fold (0.27 log units) away from the limit.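

In this assay compound 3 gives < 50200 nM, which is a limit of the assay and not a number. Methoxy in place of hydrogen on this aromatic carbon, ortho to a methoxy group and meta to a methoxy group, gives an at least 1.8-fold lower number from compound 2 to compound 3 (0.25 log units; that floor lies within the scatter), so this is the first direct reading of an added methoxy group on this ring, and it points to a lower number, though the floor of the step does not clear the scatter and its full size stays unknown. The reading at this position rests on a limit alone: the limit of < 50200 nM in this assay, at which 1 of the 3 values shown sits.

The compounds shown leave open whether a hydroxy group or an amine on this same carbon would give a number that can be set against compound 2. Also open, going by these compounds, is what a longer chain carrying the same ring would give.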